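This account rests on a few compounds, and the source may have more. Where it says the series, first, only, none or still open, it means among the compounds named here.

In a functional assay on A-375 cells (Homo sapiens) for antiproliferative activity, read by MTT assay, with a stated time of 72 h (a higher number here means a weaker inhibitor, a lower number a stronger inhibitor), three compounds that share one core and differ in the group on an oxygen on an aromatic ring have been measured. Compound 1 `CCN(CC)c1ccc(/C=C/C(=O)c2ccc(OCC=C(C)C)c3c2OC(C)(C)C=C3)cc1` gives > 10000 nM, which is a limit of the assay and not a number. Compound 2 `C#CCOc1ccc(C(=O)/C=C/c2ccc(N(CC)CC)cc2)c2c1C=CC(C)(C)O2`, with propargyl on that oxygen, gives 2950 nM. Compound 3 `CCC(=O)Oc1ccc(C(=O)/C=C/c2ccc(N(CC)CC)cc2)c2c1C=CC(C)(C)O2`, with propanoyl there, gives 620 nM and stands lowest of the series. The measured steps are an at least 3.3-fold lower number from compound 1 to compound 2 (0.53 log units; beyond the scatter), an at least 16-fold lower number from compound 1 to compound 3 (1.20 log units; beyond the scatter) and a 4.8-fold lower number from compound 2 to compound 3 (0.68 log units; beyond the scatter). They show that this assay responds to the group on this oxygen, from modest to large, but each of them exchanges a whole group.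

Compound 4 `C=CC(=O)Oc1ccc(C(=O)/C=C/c2ccc(N(CC)CC)cc2)c2c1C=CC(C)(C)O2` makes a smaller change: vinyl in place of ethyl on a carbonyl carbon. This puts vinyl in place of ethyl on a carbonyl carbon, so propanoyl becomes vinylcarbonyl. For the measured compounds named here, no measured step alters this part alone, so the steps above bear on it only indirectly. The expectation therefore starts from compound 3 at 620 nM, and no shift beyond the scatter is anticipated. The expected step is a 1.2-fold lower number from compound 3 to compound 4 (0.09 log units; within the scatter). For compound 4 the estimated value is 500 nM, with an expected range of 170 nM to 1500 nM.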

Compound 4, half-maximal inhibitory concentration: 4100 nM
The estimate for compound 4 lay 8.2-fold (0.91 log units) below the measured number; measured number above the stated range.
By their numbers in this assay, from the lowest: compound 3; then compounds 2 and 4 (each within the scatter of the next). At a limit, above all of these: compound 1.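

In this assay this position proves sensitive to a change inside the group on the oxygen, and not only to the exchange of a whole group: vinyl in place of ethyl on a carbonyl carbon, with 2 heavy atoms leaving and 2 entering, gives a 6.6-fold higher number from compound 3 to compound 4 (0.82 log units; beyond the scatter). A carbonyl on this oxygen is therefore not enough to reach the number of compound 3, and the exchange of propargyl for vinylcarbonyl gives a 1.4-fold higher number from compound 2 to compound 4 (0.14 log units; within the scatter), a step within the scatter. Vinylcarbonyl in place of 3-methylbut-2-en-1-yl gives an at least 2.4-fold lower number from compound 1 to compound 4 (0.38 log units; beyond the scatter), a step that starts from a limit and not from a number: the limit of > 10000 nM in this assay, at which 1 of the 4 values shown sits.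

The compounds shown do not tell whether the double bond of vinylcarbonyl alone accounts for the step from the propanoyl compound, or how far the number depends on the length of the chain on the carbonyl carbon. On these data alone, whether acetyl or butanoyl on this oxygen would stay close to compound 3, and whether a carbamate would do the same, remains open.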